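The compounds below may be only part of what the source reports. "The series", "measured", "known", "first", "only" and "open" are said of these compounds alone.

Compound 1 `N#Cc1ccc(-c2ccc(CO[C@@H]3COc4nc([N+](=O)[O-])cn4C3)s2)cc1` — in an ADME assay on Vero cells (Chlorocebus sabaeus) for cytotoxicity, with a stated time of 72 h (a lower number here means a stronger inhibitor, a higher number a weaker inhibitor), compound 1 gives > 128000 nM, which is a limit of the assay and not a number.
Compound 2 `O=[N+]([O-])c1cn2c(n1)OC[C@@H](OCc1csc(-c3ccc(C(F)(F)F)cc3)n1)C2` — in this assay compound 2 gives > 128000 nM, again a limit.
Compound 3 `N#Cc1ccc(-c2nc(CO[C@@H]3COc4nc([N+](=O)[O-])cn4C3)cs2)cc1` — in this assay compound 3 gives > 128000 nM, again a limit.

The three measured compounds share one core and differ only in the group on the outer six-membered ring. Going by the values given here, compound 3 stands where everything else stands: at the limit, so that the limit of > 128000 nM in this assay, at which 3 of the 3 values shown sit, sums up the whole set, and no compound can be called more or less toxic than another. Among the compounds with values here, the only single-point step among them, a step that the two limits leave unreadable from compound 2 to compound 3, has limits at both ends, so its size cannot be read.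

Compound 4 `O=[N+]([O-])c1cn2c(n1)OC[C@@H](OCc1csc(-c3ccc(F)cc3)n1)C2` differs from compound 3 by fluoro in place of cyano on an aromatic carbon. Within the data shown here, no measured step speaks to the size of this change. On the strength of the limit of > 128000 nM in this assay, at which 3 of the 3 values shown sit, compound 4 is expected to remain at or near the limit, with a step that the limit leaves unreadable from compound 3 to compound 4 not beyond the scatter. The estimate for compound 4 in this assay is 150000 nM, in a range from 60000 nM to 400000 nM.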

Compound 4, half-maximal inhibitory concentration: > 128000 nM
Compound 4 ended at the assay's limit; the forecaster's own chance of this, stated with the estimate: 85%; the middle value is on the limit's open side.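

Compound 4 also stands at a limit of the assay and not at a number, so the steps to it from compound 2 and compound 3 cannot be read. The compounds shown leave open whether cyano, trifluoromethyl or fluoro makes any difference in this assay: the limit of > 128000 nM in this assay, at which 4 of the 4 values shown sit.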